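This account rests on a few compounds, and the source may have more. Where it says the series, first, only, none or still open, it means among the compounds named here.

In a functional assay on HCT-116 cells (Homo sapiens) for cytotoxicity, read by MTT assay, with a stated time of 72 h (on this read-out lower numbers stand for stronger inhibition and higher numbers for weaker inhibition), compound 1 `O=C1c2c[n+]([O-])c3ccccc3c2C(=O)c2c1c1ccccc1n2Cc1cn([C@@H]2C[C@H](O)[C@@H](CO)O2)nn1` gives 50 nM, compound 2 `CC1(C)OCC(Cn2cc(Cn3c4c(c5ccccc53)C(=O)c3c[n+]([O-])c5ccccc5c3C4=O)nn2)O1` gives 70 nM and compound 3 `O=C1c2c[n+]([O-])c3ccccc3c2C(=O)c2c1c1ccccc1n2CCN1CCCC1` gives 270 nM. Compound 3 therefore has the highest of the three numbers, beyond the scatter of both others.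

Compound 4 `CN1CCN(CCCCCCn2c3c(c4ccccc42)C(=O)c2c[n+]([O-])c4ccccc4c2C3=O)CC1` has not yet been measured in this assay. It differs from compound 3 in the side chain: 4-(4-methylpiperazin-1-yl)butyl in place of pyrrolidin-1-yl on a saturated chain carbon, two bonds along the chain from an aromatic nitrogen. The change lies on a saturated chain carbon, two bonds along the chain from an aromatic nitrogen.

Going by the values given here, only one measured step links two compounds that differ in one place: a 1.4-fold higher number from compound 1 to compound 2 (0.15 log units; within the scatter), within the scatter, with (2,2-dimethyl-1,3-dioxolan-4-yl)methyl in place of 4-hydroxy-5-(hydroxymethyl)oxolan-2-yl on an aromatic nitrogen. That exchange involves different groups, so it bears on the present change only loosely. It does show one large side-chain exchange with no shift beyond the scatter. Among the compounds with values here, no measured pair tests pyrrolidin-1-yl against 4-(4-methylpiperazin-1-yl)butyl, so the expectation remains wide.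

The expected outcome is a 1.4-fold lower number from compound 3 to compound 4 (0.13 log units; within the scatter), an estimated step that stays within the scatter, with a slight lean toward the lower numbers seen for the other two compounds. For compound 4 the estimate is 200 nM, with an expected range of 70 nM to 550 nM.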

Compound 4, half-maximal inhibitory concentration: 2900 nM
Compound 4: middle estimate off by 15-fold (1.16 log units), on the low side, outside the stated range (above it).
By their numbers in this assay, from the lowest: compounds 1 and 2 (each within the scatter of the next); then compound 3; then compound 4.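

In this assay, the exchange on a saturated chain carbon, two bonds along the chain from an aromatic nitrogen, gives a large step: an 11-fold higher number from compound 3 to compound 4 (1.03 log units; beyond the scatter). Going by these compounds alone, the only earlier step between compounds differing in one place, a 1.4-fold higher number from compound 1 to compound 2 (0.15 log units; within the scatter), involves other groups at another place and stays within the scatter, so this is the first sign that a side-chain exchange can move the number well beyond it. Here pyrrolidin-1-yl, with 5 heavy atoms and one five-membered ring, gives way to 4-(4-methylpiperazin-1-yl)butyl, with 11 heavy atoms and one six-membered ring, and no data at hand explain the rise in the number.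

Chain extension and the change of ring occur together in compound 4, so the compounds shown do not separate their contributions to the step. Also open, going by these compounds, is how a morpholine or a dimethylamino group on the side chain of compound 3 would read in this assay, and whether a longer chain ending in pyrrolidin-1-yl would follow compound 3 or compound 4.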